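Butyl to sec-butyl on the aromatic nitrogen: working notes

The source may report more compounds than this note shows. Statements on the series, on what has been measured and on what is new or still open speak of the compounds shown alone.

Measured in a functional assay on FaDu cells (Homo sapiens) for cytotoxicity, read by MTT assay, with a stated time of 72 h (on this read-out lower numbers stand for higher toxicity in this test and higher numbers for lower toxicity in this test), so far:
- compound 1, `COc1ccc(NC(=O)C(=O)c2cn(C(C)C)c3ncccc23)cn1`: 126 nM
- compound 2, `CCCCn1cc(C(=O)C(=O)Nc2ccc(OC)nc2)c2ccccc21`: 18 nM
- compound 3, `CCn1cc(C(=O)C(=O)Nc2ccnc(OC)c2)c2ccccc21`: 4180 nM

Compound 2 gives the lowest number of the three in this assay and is the most cytotoxic: compound 1 sits a step higher that is beyond the scatter, and compound 3 sits far higher still, also beyond the scatter. Compound 1 and compound 3 each differ from compound 2 in more than one place, so none of these pairs gives a clean single-change step.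

The next compound is compound 4, `CCC(C)n1cc(C(=O)C(=O)Nc2ccc(OC)nc2)c2ccccc21`, not yet measured. It differs from compound 2 in one place: sec-butyl in place of butyl on an aromatic nitrogen. Within the data shown here, the two compounds have the same atoms joined differently, and no measured pair tells what rearranging this group on the aromatic nitrogen does here. The change is expected to be small, a step from compound 2 to compound 4 of a 1.7-fold higher number from compound 2 to compound 4 (0.22 log units; within the scatter), most likely no more than the scatter and, if anything, toward a somewhat higher number. Compound 4 is therefore expected to give about 30 nM in this assay, within the range 8 nM to 120 nM.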

Compound 4, concentration lethal to 50% of the cells: 68 nM
The estimate for compound 4 lay 2.3-fold (0.36 log units) below the measured number; the range from low to high includes it.
By their numbers in this assay, from the lowest: compound 2; then compounds 4 and 1 (each within the scatter of the next); then compound 3.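

In this assay, the series now has its first single-change step at the aromatic nitrogen: a 3.8-fold higher number from compound 2 to compound 4 (0.58 log units; beyond the scatter), with sec-butyl in place of butyl. The two groups match in everything counted for them, including heavy atoms, carbon content, absence of a ring, hydrogen-bond donors and acceptors, and net charge, yet the step lies beyond the scatter, showing that this position responds to how the same atoms are joined and not only to which atoms are present. No measurement available on these compounds accounts for the step, which remains an observation without an explanation.

Still open, from the compounds shown here alone, is how a longer chain such as hexyl, a more branched tert-butyl group or a chain ending in an amine would behave on the aromatic nitrogen. Going by these compounds, it is also open whether the step from butyl to sec-butyl would keep its size on a different core.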